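The compounds below may be only part of what the source reports. "The series", "measured", "known", "first", "only" and "open" are said of these compounds alone.

Measured compounds:
- compound 1, `COc1cc(N/C=C\C(=O)c2cn(-c3ccccc3)nc2-c2ccccc2)cc(OC)c1OC`, which in a functional assay on U-87MG ATCC cells (Homo sapiens) for antiproliferative activity, read by MTT assay, with a stated time of 48 h (on this read-out lower numbers stand for stronger inhibition and higher numbers for weaker inhibition), gives 2350 nM
- compound 2, `O=C(/C=C\Nc1ccc(F)cc1)c1cn(-c2ccccc2)nc1-c1ccc(F)cc1`, which in this assay gives 18200 nM

Of the two numbers, compound 1 has the lower one, and compound 2 sits at a higher number, a gap that lies beyond the scatter. Going by the values given here, compound 2 differs from compound 1 in more than one place, so no single step between them can be read, and their two values show only that order.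

Compound 3, `COc1cc(N/C=C\C(=O)c2cn(-c3ccccc3)nc2-c2ccc(Cl)cc2)cc(OC)c1OC`, has not yet been measured in this assay. Relative to compound 1 the change is chloro in place of hydrogen on an aromatic carbon, placed on an aromatic carbon of a six-membered aromatic ring of carbon only, para to a large group; cut one bond further out it reads phenyl to 4-chlorophenyl. Among the compounds with values here, no measured pair isolates this change, so the size of the step rests on no direct precedent. A small step in this assay is expected, not beyond the scatter in either direction. For compound 3 the expected result is 1800 nM, with a range from 600 nM to 5500 nM, a step of a 1.3-fold lower number from compound 1 to compound 3 (0.12 log units; within the scatter) anticipated.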

Compound 3, half-maximal inhibitory concentration: 17800 nM
Compound 3: the middle estimate sits 9.9-fold (1.00 log units) below what was measured, and the stated range ends below it.
By their numbers in this assay, from the lowest: compound 1; then compounds 3 and 2 (each within the scatter of the next).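

In this assay, the change from phenyl to 4-chlorophenyl comes with a 7.6-fold higher number from compound 1 to compound 3 (0.88 log units; beyond the scatter), toward weaker inhibition. Going by these compounds alone, this pair is the first to isolate a single change, and it shows that this place on the core of compound 1, on a six-membered aromatic ring of carbon only and para to a large group, is not indifferent to substitution: one chlorine atom in place of a hydrogen atom is enough to carry the number beyond the scatter. Nothing in the data shown accounts for the size of this step.

One pair cannot tell whether the step belongs to chloro in particular or would follow any group at this place, and a fluoro, methyl, methoxy or amine group there would separate those two readings. As far as these compounds go, it also remains open whether chloro would bring a step of similar size if the rest of compound 1 were changed, since this change has been read only once, against a single parent.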